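The compounds below may be only part of what the source reports. "The series", "measured", "known", "first", "only" and "open" are said of these compounds alone.

In a functional assay on KB cells (Homo sapiens) for antiproliferative activity, read by sulforhodamine B assay, with a stated time of 3 days (a lower number here means that less compound is needed, a higher number that more compound is needed for the effect), three compounds sharing one core have been tested. Compound 1 `CCC1=C(O)c2c(oc(-c3ccc(C)cc3)cc2=O)C(CC)(CC)C1=O`, which carries a methyl on an aromatic carbon, gives 39.2 uM. Compound 2 `CCOc1ccc(-c2cc(=O)c3c(o2)C(CC)(CC)C(=O)C(CC)=C3O)cc1`, with ethoxy there, gives only a limit of > 52.4 uM. Compound 3 `CCCOc1ccc(-c2cc(=O)c3c(o2)C(CC)(CC)C(=O)C(CC)=C3O)cc1`, with propoxy there, also gives only a limit, > 50.5 uM. Compound 3 therefore has no number of its own on this scale.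

Compound 4 `CCC1=C(O)c2c(oc(-c3ccc(Br)cc3)cc2=O)C(CC)(CC)C1=O` follows with bromo in place of propoxy on an aromatic carbon. Going by the values given here, no measured step brings in bromo, so the nearest guides are the steps at this same place. They are an at least 1.3-fold higher number from compound 1 to compound 2 (0.12 log units; that floor lies within the scatter) and an at least 1.2-fold higher number from compound 1 to compound 3 (0.11 log units; that floor lies within the scatter), and both floors lie within the scatter. The change in the chain, a step that the two limits leave unreadable from compound 2 to compound 3, adds nothing readable. A modest move to a lower number in this assay is expected, though it may not clear the scatter. The expected step is an at least 1.4-fold lower number from compound 3 to compound 4 (0.15 log units; that floor lies within the scatter). Compound 4 is estimated at 35 uM, with an expected range from 15 uM to 70 uM.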

Compound 4, concentration for half-maximal effect: > 48.1 uM
Compound 4 gave a limit, no number; the forecaster's own chance of this, stated with the estimate: 30%; at least 1.3-fold (0.13 log units) between middle value and limit.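

In this assay compound 4, like compounds 2 and 3, has only a limit and no number of its own: the limit of > 48.1 uM in this assay, at which 1 of the 4 values shown sits. Bromo on this aromatic carbon, para to a large group, therefore leaves compound 1, with methyl, as the only one of the four compounds with a number on this scale, even though bromo is a single heavy atom and propoxy has four. The change from methyl to bromo gives an at least 1.2-fold higher number from compound 1 to compound 4 (0.08 log units; that floor lies within the scatter), and the steps from compounds 2 and 3 to compound 4 cannot be read, so no order can be set among these groups.

Going by these compounds, the actual numbers of compounds 2, 3 and 4 remain open. Also open, on these data alone, is whether an amine or a carboxylic acid at this place would give a lower number than compound 1 does, at 39.2 uM.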